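Chain extension on the amino side of the shared core

The compounds below may be only part of what the source reports. "The series", "measured", "known", "first", "only" and "open" are said of these compounds alone.

Working notes on the series. For the measured compounds named here, compound 2 `CCCCNc1nc(SC(C)C)nc2ncccc12` is the higher of the two numbers so far: in a functional assay on HT-29 cells (Homo sapiens) for cytotoxicity, read by neutral red uptake, with a stated time of 72 h (a higher number here means a weaker inhibitor, a lower number a stronger inhibitor), compound 2 gives 32100 nM, while compound 1 `CCCCCNc1nc(SCC)nc2ncccc12`, which carries a longer chain on the amine and a smaller group on the sulfur, gives 5100 nM, a gap that lies beyond the scatter. Going by the values given here, no single-change step links these two, so their values are simply set side by side.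

Compound 3 `CCCCCNc1nc(SC(C)C)nc2ncccc12` is not yet measured. It differs from compound 2 by methyl in place of hydrogen on a saturated chain carbon, four bonds along the chain from a nitrogen on an aromatic ring, which turns the butyl chain into a pentyl chain while the isopropyl on the sulfur stays as in compound 2.

Among the compounds with values here, with no directly comparable step available, the step of a 2.7-fold lower number from compound 2 to compound 3 (0.43 log units; beyond the scatter) is expected to be modest, towards a lower number, given that compound 1 with the same pentyl chain gives 5100 nM. Compound 3 is therefore estimated at 12000 nM, in the range 4000 nM to 40000 nM.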

Compound 3, half-maximal inhibitory concentration: 25200 nM
Compound 3: middle estimate off by 2.1-fold (0.32 log units), on the low side; the measured number falls inside the stated range.
By their numbers in this assay, from the lowest: compound 1; then compounds 3 and 2 (each within the scatter of the next).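

With the isopropyl on the sulfur held fixed, going from the butyl chain to the pentyl chain on the amine makes no change beyond the scatter (a 1.3-fold lower number from compound 2 to compound 3 (0.11 log units; within the scatter)) in this assay. For the compounds shown here, with the pentyl chain held fixed, methyl in place of hydrogen on a saturated chain carbon bound to a saturated chain carbon and a sulfur, which turns ethyl into isopropyl, gives a step beyond the scatter (a 4.9-fold higher number from compound 1 to compound 3 (0.69 log units; beyond the scatter)), so of the two single changes only the one at the sulfur separates its compounds. No measurement available here accounts for either step.

The compounds shown leave open whether a longer chain on the amine, such as hexyl, would also stay within the scatter of compound 3. They also leave open where a methyl or a tert-butyl group on the sulfur would fall relative to ethyl and isopropyl.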